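Antiproliferative series: 1-hydroxyethyl in place of carbamoyl

The compounds below may be only part of what the source reports. "The series", "measured", "known", "first", "only" and "open" are said of these compounds alone.

Among the compounds with values here, compound 2 `CCCCCCCC/[N+]([O-])=N/[C@@H](COC)C(N)=O` is the only member of the series with a number in a functional assay on K562 cells (Homo sapiens) for antiproliferative activity; a lower number here means a stronger inhibitor of growth, a higher number a weaker inhibitor of growth; compound 2 gives 37.5 ug/mL. Compound 1 `COC[C@H](/N=[N+](\[O-])CCCCCCC(C)=O)[C@H](C)O` is reported only as a limit of the assay: in this assay compound 1 gives > 50 ug/mL. Compound 2 therefore stands as the one quantified point, while the other value sits at the limit of > 50 ug/mL in this assay, at which 1 of the 2 values shown sits.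

Compound 3 `CCCCCCCC/[N+]([O-])=N/[C@@H](COC)[C@H](C)O` has not yet been measured in this assay. It differs from compound 2 by 1-hydroxyethyl in place of carbamoyl on a saturated chain carbon bound to a double-bonded nitrogen and a saturated chain carbon. Within the data shown here, no measured pair isolates this change, so the size of the step rests on expectation alone. Compound 3 is expected to show a step of a 1.2-fold higher number from compound 2 to compound 3 (0.08 log units; within the scatter) that stays within the usual scatter, with a real chance that only a limit is reported. The estimate for compound 3 in this assay is 45 ug/mL, within a range from 20 ug/mL to 100 ug/mL.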

Compound 3, concentration for 50% growth inhibition: > 50 ug/mL
Compound 3: a limit, no number; the forecaster's own chance of this, stated with the estimate: 45%; middle value at least 1.1-fold (0.04 log units) away from the limit.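

In this assay compound 3 gives > 50 ug/mL, which is a limit and not a number. As far as these compounds go, putting 1-hydroxyethyl in place of carbamoyl at this saturated chain carbon gives an at least 1.3-fold higher number from compound 2 to compound 3 (0.12 log units; that floor lies within the scatter), so the readable floor of this change stays within the scatter, while its full size remains unknown. Carbamoyl is so far the only group at this position tied to a quantified value, and most of the series now rests on a single limit: the limit of > 50 ug/mL in this assay, at which 2 of the 3 values shown sit.

The step between compound 1 and compound 3 cannot be read, as both values are limits. From the compounds shown here alone, whether an amine or a carboxylic acid in place of carbamoyl at this carbon would give a quantified value remains open.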